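Furan-2-yl for bromo in a flat series: expected outcome

This account rests on a few compounds, and the source may have more. Where it says the series, first, only, none or still open, it means among the compounds named here.

Measured so far:
compound 1 `CC(C)(C)Cc1c(-c2ccc(Cl)cc2)sc(N)c1C(=O)c1ccc(Cl)cc1`: 1%
compound 2 `CC(C)(C)Cc1c(-c2ccc(Cl)c(Cl)c2)sc(N)c1C(=O)c1ccc(Cl)cc1`: 1%
compound 3 `CC(C)(C)Cc1c(Br)sc(N)c1C(=O)c1ccc(Cl)cc1`: 1%

In an assay on CHO cells for displacement of a labelled ligand from adenosine receptor A3 (Homo sapiens), read by scintillation counting, tested at 10 uM (on this read-out lower numbers stand for less inhibition and higher numbers for more inhibition at the one concentration tested (going by the name of the read-out)), the three compounds sit together: compound 3 is level with compounds 1 and 2, with no change at the digits printed from compound 1 to compound 3 (within the scatter) and no change at the digits printed from compound 2 to compound 3 (within the scatter) both within the scatter, as is no change at the digits printed from compound 1 to compound 2 (within the scatter) between the two aryl analogues. Compound 4 `CC(C)(C)Cc1c(-c2ccco2)sc(N)c1C(=O)c1ccc(Cl)cc1` carries the change (furan-2-yl in place of bromo on an aromatic carbon). Going by the values given here, the steps that bear on it are those exchanging a substituent at the same ring carbon, namely from compound 1 and from compound 2 to compound 3, and neither moved the read-out. A step of a number 1 percentage points higher from compound 3 to compound 4 (within the scatter) is therefore expected, that is no shift beyond the scatter. Compound 4 is estimated at 2%, within 0% to 14%.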

Compound 4, a percentage reported as inhibition, at one concentration (the size of the read-out at that concentration, not a potency): 1%
Compound 4: the middle estimate sits 1 percentage points above what was measured; the range from low to high includes it.
By their numbers in this assay, from the lowest: compounds 1, 2, 3 and 4 (each within the scatter of the next).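

A hydrogen-bond acceptor now stands on this carbon next to the ring sulfur, and in this assay furan-2-yl in place of bromo gives no change at the digits printed from compound 3 to compound 4 (within the scatter). Set against the aryl groups, furan-2-yl gives no change at the digits printed from compound 2 to compound 4 (within the scatter) and no change at the digits printed from compound 1 to compound 4 (within the scatter), so the four groups shown at this position do not separate. Nothing available explains this flat read-out.

Going by these compounds, whether a carbon-linked amine or a carboxylic acid at this carbon would lift the read-out stays open. So does whether replacing the neopentyl group with a shorter chain would.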